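The source may hold more compounds than are shown below. What is called first, only, known or untested is meant among the compounds shown, and "the series" means these compounds.

In a functional assay on MCF7 cells (Homo sapiens) for antiproliferative activity, read by MTT assay, with a stated time of 72 h (a higher number here means a weaker inhibitor, a lower number a stronger inhibitor), compound 2 `CC1=CC[C@H]2[C@H](CC[C@]2(C)O)C(C)(C)[C@@H]1CC[C@H]1[C@]2(C)CC[C@H](OC(=O)NS(=O)(=O)c3ccc(C)cc3)C(C)(C)O[C@H]2CC[C@@]1(C)O` gives > 50000 nM, which is a limit of the assay and not a number. Compound 3 `CC1=CC[C@H]2[C@H](CC[C@]2(C)O)C(C)(C)[C@@H]1CC[C@H]1[C@]2(C)CC[C@H](OC(=O)c3ccc(F)cc3)C(C)(C)O[C@H]2CC[C@@]1(C)O` carries 4-fluorophenyl in place of ((4-methylphenyl)sulfonyl)amino on a carbonyl carbon. Compound 1 `CC1=CC[C@H]2[C@H](CC[C@]2(C)O)C(C)(C)[C@@H]1CC[C@H]1[C@]2(C)CC[C@H](OC(=O)c3ccc(Cl)cc3)C(C)(C)O[C@H]2CC[C@@]1(C)O` gives 24100 nM. Among the compounds with values here, the one measured step that bears on this change, an at least 2.0-fold higher number from compound 1 to compound 2 (0.31 log units; beyond the scatter), brought in that same ((4-methylphenyl)sulfonyl)amino group, and its true size remains open. The reverse kind of swap is therefore expected to lower the number in this assay, by a similar modest amount: an at least 2.0-fold lower number from compound 2 to compound 3 (0.30 log units; that floor lies within the scatter). Compound 3 is estimated at 25000 nM, with an expected range from 11000 nM to 50000 nM.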

Compound 3, half-maximal inhibitory concentration: 33500 nM
The estimate for compound 3 lay 1.3-fold (0.13 log units) below the measured number; the range from low to high includes it.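

In this assay, fluoro in place of chloro on an aromatic carbon gives a 1.4-fold higher number from compound 1 to compound 3 (0.14 log units; within the scatter), so compound 1 and compound 3 cannot be told apart at this halogen. Putting 4-fluorophenyl in place of ((4-methylphenyl)sulfonyl)amino on a carbonyl carbon gives an at least 1.4-fold lower number from compound 2 to compound 3 (0.17 log units; that floor lies within the scatter). The true size of that step stays open because compound 2 carries a limit of the assay and not a number: the limit of > 50000 nM in this assay, at which 1 of the 3 values shown sits.

As far as these compounds go, whether an amine or a carboxylic acid in place of the halogen on that aromatic carbon would move the number much further remains open.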